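The source may report more compounds than this note shows. Statements on the series, on what has been measured and on what is new or still open speak of the compounds shown alone.

In a functional assay on HL-60 cells (Homo sapiens), with a stated time of 4 days (on this read-out lower numbers stand for stronger inhibition and higher numbers for weaker inhibition), compound 1 `O=C(Nc1ccc(Cl)c(Cl)c1)c1nc[nH]c1C(=O)NCc1ccc(Cl)cc1` gives 8800 nM. Compound 3 `C[C@@H](NC(=O)c1[nH]cnc1C(=O)Nc1ccc(Cl)c(Cl)c1)c1ccccc1` gives 5900 nM, and compound 2 `O=C(NCc1ccc(-c2ccccc2)cc1)c1nc[nH]c1C(=O)Nc1ccc(Cl)c(Cl)c1` gives 2900 nM, a lower number than compound 1 shows. Compound 4 `COC(=O)[C@@H](C)NC(=O)c1[nH]cnc1C(=O)Nc1ccc(Cl)c(Cl)c1` has 1-(methoxycarbonyl)ethyl in place of 4-chlorobenzyl on an amide-type nitrogen. Among the compounds with values here, the one measured step at this place is a 1.5-fold lower number from compound 1 to compound 3 (0.17 log units; within the scatter), with 1-phenylethyl as the incoming group. Within the data shown here, that group still holds an aromatic ring, and no measured compound lacks one there, so the evidence is thin and gives no direction. The expected change is a 1.1-fold higher number from compound 1 to compound 4 (0.06 log units; within the scatter), so no shift beyond the scatter is anticipated in this assay. For compound 4 the estimated value is 10000 nM, with an expected range from 4000 nM to 25000 nM.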

Compound 4, half-maximal inhibitory concentration: > 62500 nM
Compound 4: no number, only a limit; the forecaster's own chance of this, stated with the estimate: 10%; middle value at least 6.2-fold (0.79 log units) away from the limit.
By their numbers in this assay, from the lowest: compound 2; then compounds 3 and 1 (each within the scatter of the next). At a limit, above all of these: compound 4.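

In this assay compound 4 gives > 62500 nM, which is a limit and not a number. Within the data shown here, on this amide-type nitrogen, 1-(methoxycarbonyl)ethyl in place of 4-chlorobenzyl brings an at least 7.1-fold higher number from compound 1 to compound 4 (0.85 log units; beyond the scatter), so this place can shift the read-out further than the earlier compounds showed. Methoxycarbonyl in place of phenyl brings an at least 10-fold higher number from compound 3 to compound 4 (1.02 log units; beyond the scatter), and the three compounds with measured numbers all keep an aromatic ring here. Still open, on these data alone, is whether losing that ring or gaining the ester counts more. A carboxylic acid, an amide or a plain butyl chain at this place could separate the two.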